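Replacing the Group on the Ring Nitrogen: What to Expect

A few compounds are considered here, and "the series" means these few. Any claim that something is new, unique, unknown or untested is made for them only; others in the source may bear on it.

Of the compounds shown here, two sharing one core have been tested in an ADME assay on microsomes from liver (Rattus norvegicus) for metabolic stability, read by LC-MS, using NADPH, with a stated time of 60 min, tested at 10 uM; a higher number here means that more of the compound is left, a lower number that less of the compound is left. Compound 1 `[O-][S+](CCNC1CCN(Cc2ccc(F)cc2)CC1)C(c1ccc(F)cc1)c1ccc(F)cc1` gives 95%, while compound 2 `[O-][S+](CCNC1CCN(CC(O)Cc2ccccc2)CC1)C(c1ccc(F)cc1)c1ccc(F)cc1` gives 22%, the lower of the two numbers. Within the data shown here, the single measured change between them is a number 73 percentage points lower from compound 1 to compound 2 (beyond the scatter). Compound 3 `O=C(c1ccc(F)cc1)N1CCC(NCC[S+]([O-])C(c2ccc(F)cc2)c2ccc(F)cc2)CC1` differs from compound 2 in one place: (4-fluorophenyl)carbonyl in place of 2-hydroxy-3-phenylpropyl on an amine nitrogen in a ring. This change relates to the earlier step because a number 73 percentage points lower from compound 1 to compound 2 (beyond the scatter) removed a 4-fluorophenyl ring from the amine nitrogen in a ring, and compound 3 brings such a ring back, now attached through a carbonyl rather than a saturated chain carbon. Among the measured compounds shown here, since the one measured step was large, a sizable step upward in this assay is expected for compound 3, though the new group is not identical to that in compound 1, so the estimate is uncertain. In this assay compound 3 is expected to give 70%, within a range from 40% to 95%. The expected change is a number 48 percentage points higher from compound 2 to compound 3 (beyond the scatter).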

Compound 3, percent of the compound remaining: 79%
Compound 3: the middle estimate sits 9 percentage points below what was measured, within the range that was stated.
By their numbers in this assay, from the lowest: compound 2; then compound 3; then compound 1.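

On the amine nitrogen in a ring, the step of a number 57 percentage points higher from compound 2 to compound 3 (beyond the scatter) shows that in this assay a high number returns when (4-fluorophenyl)carbonyl replaces 2-hydroxy-3-phenylpropyl. The step of a number 16 percentage points lower from compound 1 to compound 3 (beyond the scatter) is only modest, so with the 4-fluorophenyl ring kept in place, exchanging the saturated chain carbon of 4-fluorobenzyl for a carbonyl changes the number far less than the move to 2-hydroxy-3-phenylpropyl did. No measurement here explains why these numbers differ.

The 2-hydroxy-3-phenylpropyl group differs from the other two groups in its hydroxyl, its longer chain and its lack of fluorine, and these compounds cannot separate those features. A 3-phenylpropyl group without the hydroxyl, or a plain benzyl group without the fluorine, would help to tell them apart.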